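Naphthyl Sulfonamide Replaces Tolyl in a Chemokine Receptor Binder

A few compounds are considered here, and "the series" means these few. Any claim that something is new, unique, unknown or untested is made for them only; others in the source may bear on it.

Measured compounds:
Compound 1 `O=C(NCc1ccc(CNS(=O)(=O)c2ccccc2)cc1)c1ccc(CNc2ncccn2)cc1` gives 1 nM in an assay on MDA-MB-231 cells for binding affinity to C-X-C chemokine receptor type 4 (Homo sapiens), read by microscopy, with stated times of 10 min and 30 min; on this read-out lower numbers stand for an effect already at smaller amounts and higher numbers for an effect only at larger amounts of compound.
Compound 2 `Cc1ccc(S(=O)(=O)NCc2ccc(CNC(=O)c3ccc(CNc4ncccn4)cc3)cc2)cc1` gives 100 nM in this assay.

Compound 2 stands highest of the two numbers; its nearest neighbour is compound 1, and the step of a 100-fold higher number from compound 1 to compound 2 (2.00 log units; beyond the scatter) is large and beyond the scatter. Compound 3 `O=C(NCc1ccc(CNS(=O)(=O)c2cccc3ccccc23)cc1)c1ccc(CNc2ncccn2)cc1` has not yet been measured. It differs from compound 2 at one place: naphthalen-1-yl in place of 4-methylphenyl on a sulfonyl sulfur. Within the data shown here, the only measured step, a 100-fold higher number from compound 1 to compound 2 (2.00 log units; beyond the scatter), concerns the same aromatic group on the sulfonyl sulfur and shows that this assay answers strongly to changes there. Among the measured compounds shown here, in compound 3 the 4-methylphenyl leaves, which points back toward compound 1, but the naphthalen-1-yl that enters is a larger group with two rings, and no measured compound tells how this assay receives it. The expected outcome is therefore a step of a 10-fold lower number from compound 2 to compound 3 (1.00 log units; beyond the scatter), in the direction of a lower number, with wide uncertainty. For compound 3 the estimate is 10 nM, between 1 nM and 100 nM.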

Compound 3, effective concentration (reported as EC, without a stated level of effect): 1000 nM
The estimate for compound 3 lay 100-fold (2.00 log units) below the measured number; the measured number lies above the stated range.
By their numbers in this assay, from the lowest: compound 1; then compound 2; then compound 3.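

The naphthalen-1-yl group does not bring back what was lost when the phenyl of compound 1 became the 4-methylphenyl of compound 2: in this assay the change gives a 10-fold higher number from compound 2 to compound 3 (1.00 log units; beyond the scatter) and, set against the plain phenyl, a 1000-fold higher number from compound 1 to compound 3 (3.00 log units; beyond the scatter) in the same direction. Among these three compounds, then, the unadorned phenyl on the sulfonyl sulfur has the lowest number, and both the added methyl and the second aromatic ring go with higher numbers. The compounds shown leave open how this assay would answer to a pyridine ring, a 4-methoxyphenyl or a simple methyl on the sulfonyl sulfur. Why a single methyl and a second ring both raise the number also stays unexplained, as no supporting information on this result is available.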